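A few compounds are considered here, and "the series" means these few. Any claim that something is new, unique, unknown or untested is made for them only; others in the source may bear on it.

Measured compounds:
Compound 1, `CC1(COc2ccc(Cl)cc2)CCn2cc([N+](=O)[O-])nc2O1`: in an ADME assay on MRC5 cells (Homo sapiens) for cytotoxicity, read by resazurin assay, with a stated time of 72 h (a lower number here means a stronger inhibitor, a higher number a weaker inhibitor), compound 1 gives >= 40000 nM, a limit of the assay rather than a number.
Compound 2, `CC1(COc2ccc(F)cc2)CCn2cc([N+](=O)[O-])nc2O1`: in this assay compound 2 gives >= 40000 nM, likewise a limit.
Compound 3, `CC1(CNc2ccc(Cl)cc2)CCn2cc([N+](=O)[O-])nc2O1`: in this assay compound 3 gives >= 40000 nM, again a limit.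

All three values sit at the same boundary, (the limit of >= 40000 nM in this assay, at which 3 of the 3 values shown sit). Compound 1 and compound 2 differ by fluoro in place of chloro on an aromatic carbon; both ends of a step that the two limits leave unreadable from compound 1 to compound 2 are limits, so the size of that step cannot be read. The difference between the cores of compound 1 and compound 3 is not broken down here.

Compound 4, `CC1(CNc2ccc(F)cc2)CCn2cc([N+](=O)[O-])nc2O1`, is not yet measured in this assay. It differs from compound 3 by fluoro in place of chloro on an aromatic carbon, the same change as between compound 1 and compound 2. Compound 3 rests at the limit >= 40000 nM. Given that the earlier change left compound 2 at the limit as well, the expected step is a number no higher from compound 3 to compound 4 (the limit leaves the size open). Compound 4 is therefore estimated at 40000 nM, most likely reported only as a limit.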

Compound 4, half-maximal inhibitory concentration: >= 40000 nM
Compound 4 was reported as a limit; the forecaster's own chance of this, stated with the estimate: 85%; the middle value lies on the limit itself.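

No new step can be read from compound 3 to compound 4, as both values in this assay are limits of the assay: the limit of >= 40000 nM in this assay, at which 4 of the 4 values shown sit.

The compounds shown leave open where any of the four truly lies past that limit, and whether fluoro in place of chloro changes the read-out at all.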